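Replacing a Cyclic Amino Acid with an Acetamidoethylamine Tail

This account rests on a few compounds, and the source may have more. Where it says the series, first, only, none or still open, it means among the compounds named here.

Compound 1 `COc1ccc(/C=C\c2cc(OC)c(OC)c(OC)c2)cc1OCc1ccc(CN2C[C@H](O)C[C@@H]2C(=O)O)cc1` was tested in a functional assay on B16-F10 cells (Mus musculus) for antiproliferative activity, read by CCK-8 assay, with a stated time of 48 h (on this read-out higher numbers stand for weaker inhibition and lower numbers for stronger inhibition), where compound 1 gives only the limit > 10000 nM rather than a number. Compound 2 `COc1ccc(/C=C\c2cc(OC)c(OC)c(OC)c2)cc1OCc1ccc(CN2CCCCC2C(=O)O)cc1` likewise reaches only the limit > 10000 nM in this assay. Compound 3 `COc1ccc(/C=C\c2cc(OC)c(OC)c(OC)c2)cc1OCc1ccc(CN2CC[C@H](O)C2)cc1` also stands at the limit > 10000 nM. Because all three values sit at the limit of > 10000 nM in this assay, at which 3 of the 3 values shown sit, the steps a step that the two limits leave unreadable from compound 1 to compound 2, a step that the two limits leave unreadable from compound 1 to compound 3 and a step that the two limits leave unreadable from compound 2 to compound 3 cannot be read. Compound 4 `COc1ccc(/C=C\c2cc(OC)c(OC)c(OC)c2)cc1OCc1ccc(CNCCNC(C)=O)cc1` differs from compound 1 by (2-acetamidoethyl)amino in place of 2-carboxy-4-hydroxypyrrolidin-1-yl on a saturated chain carbon bound to an aromatic carbon. Going by the values given here, with every measured neighbour at the limit, no step gives a size or direction for this change in this assay. Compound 4 is therefore expected to give roughly 15000 nM, within 3000 nM to 100000 nM, most likely again as a limit. The step that the limit leaves unreadable from compound 1 to compound 4 is estimated to be none beyond the scatter.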

Compound 4, half-maximal inhibitory concentration: 2500 nM
Compound 4: the middle estimate sits 6.0-fold (0.78 log units) above what was measured, and the stated range ends above it.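

In this assay, going by these compounds alone, the open-chain (2-acetamidoethyl)amino group on this saturated chain carbon gives the first readable number in the set: an at least 4.0-fold lower number from compound 1 to compound 4 (0.60 log units; beyond the scatter), an at least 4.0-fold lower number from compound 2 to compound 4 (0.60 log units; beyond the scatter) and an at least 4.0-fold lower number from compound 3 to compound 4 (0.60 log units; beyond the scatter). So the tail at this place can move activity, which the three ring-bearing tails could not show. These steps are only minimum sizes, and the steps among compound 1, compound 2 and compound 3 cannot be read, with all three compounds at a limit: the limit of > 10000 nM in this assay, at which 3 of the 4 values shown sit.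

The compounds shown do not separate losing the ring from gaining the acetamide. A primary amine in place of the acetamide, or a longer chain carrying it, would help separate them.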